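The compounds below may be only part of what the source reports. "The series", "measured", "known", "first", "only" and "open" are said of these compounds alone.

Working notes on the series.

Among the compounds with values here, compound 1 `N/C(=N\NC(=S)N1CCCC1)c1ccc(F)cn1` stands highest of the three numbers so far: in a functional assay on MCF7 cells (Homo sapiens) for cytotoxicity, read by MTT assay, with a stated time of 72 h, tested at 1 uM (a lower number here means less inhibition of growth, a higher number more inhibition of growth at the concentration tested), compound 1 gives 51%. Compound 3 `Cc1cccc(/C(N)=N/NC(=S)N2CCCC2)n1` gives 17.4% in this assay, a gap beyond the scatter; compound 2 `N/C(=N\NC(=S)N1CCSCC1)c1ccccn1` gives 16.3%, also beyond the scatter from compound 1. Within the data shown here, compound 2 differs from compound 1 in two places, so the two values show only that the pair sits far apart.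

Compound 4 `N/C(=N\NC(=S)N1CCOCC1)c1ccc(F)cn1` differs from compound 1 by morpholin-4-yl in place of pyrrolidin-1-yl on a thiocarbonyl carbon. Among the measured compounds shown here, no measured step isolates this change; compound 2 carries a six-membered ring at the same place but with a different core. A downward step is expected, likely beyond the scatter: the step from compound 1 to compound 4 is estimated at a number 21 percentage points lower from compound 1 to compound 4 (beyond the scatter), so compound 4 is expected to give 30%, ranging from 10% to 52% in this assay.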

Compound 4, percent growth inhibition at one concentration: 12.4%
For compound 4 the middle estimate is 17.6 percentage points above the measured one, within the range that was stated.
By their numbers in this assay, from the lowest: compounds 4, 2 and 3 (each within the scatter of the next); then compound 1.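

With the core of compound 1 held fixed, morpholin-4-yl in place of pyrrolidin-1-yl on a thiocarbonyl carbon gives a large step in this assay: a number 38.6 percentage points lower from compound 1 to compound 4 (beyond the scatter). Within the data shown here, this is the first comparison that isolates a change at this place, as no earlier pair differed in one place only. No evidence on the origin of this step is available.

The compounds shown leave open whether the step follows the ring oxygen or the six-membered ring, since both change together. Piperidin-1-yl at the same place would separate the two.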